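A few compounds are considered here, and "the series" means these few. Any claim that something is new, unique, unknown or untested is made for them only; others in the source may bear on it.

Three members of this series have been measured in a functional assay on T-24 cells (Homo sapiens) for cytotoxicity, read by MTT assay, with a stated time of 2 days; on this read-out lower numbers stand for stronger inhibition and higher numbers for weaker inhibition. Compound 1 `c1ccc(CO/N=C2/C(c3c[nH]c4ccccc34)=Nc3ccccc32)cc1` gives 12200 nM. Compound 2 `N#Cc1ccc2c(c1)/C(=N\OCc1ccccc1)C(c1c[nH]c3ccc(C#N)cc13)=N2` gives 18600 nM, and compound 3 `Cc1ccc(CO/N=C2/C(c3c[nH]c4ccc(Br)cc34)=Nc3ccc(Br)cc32)cc1` gives 21400 nM. For the measured compounds named here, compound 1 carries the smallest of the three numbers, but the gaps to compound 2 and to compound 3 both fall within the usual scatter of this assay, so no ordering among the three is claimed; compound 2 and compound 3 each differ from compound 1 in more than one place, and their values show only that those combined changes left the read-out in the same range.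

Compound 4 `FC(F)(F)c1ccc(CO/N=C2/C(c3c[nH]c4ccccc34)=Nc3ccccc32)cc1` has not yet been measured in this assay. It differs from compound 1 by trifluoromethyl in place of hydrogen on an aromatic carbon. Going by the values given here, no measured pair in the set isolates this single change, so the size of the step rests on expectation only. Given that the broader substitutions seen in compound 2 at 18600 nM and compound 3 at 21400 nM stayed within the scatter of compound 1, the step from compound 1 to compound 4 is expected to be small, a 1.1-fold higher number from compound 1 to compound 4 (0.06 log units; within the scatter), with no clear direction beyond the scatter. Compound 4 is estimated at 14000 nM in this assay, with a range from 6000 nM to 35000 nM.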

Compound 4, half-maximal inhibitory concentration: 18900 nM
Compound 4: middle estimate off by 1.4-fold (0.13 log units), on the low side; measured number inside the range.
By their numbers in this assay, from the lowest: compounds 1, 2, 4 and 3 (each within the scatter of the next).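

In this assay, for the compounds shown here, the change from phenyl to 4-(trifluoromethyl)phenyl gives a 1.5-fold higher number from compound 1 to compound 4 (0.19 log units; within the scatter), and this is the first step that isolates a single place. Compounds 2 and 3 each differ from compound 1 in more than one place, so they could not show what this position tolerates on its own; this pair shows that trifluoromethyl, with its 4 heavy atoms, can replace hydrogen on this aromatic carbon, para to a large group, without moving the read-out beyond the scatter. No data accompanying this step speak to why the read-out behaves this way, so the result stands as an observation only.

Still open, on these data alone, is whether a group of a different kind at the same carbon, such as an amine, a carboxylic acid or a longer alkyl chain, would also leave the read-out within the scatter of compound 1. The compounds shown also leave open whether trifluoromethyl would give a similar step on the nitrile-bearing core of compound 2 or the bromine-bearing core of compound 3.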